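The source may hold more compounds than are shown below. What is called first, only, known or untested is meant among the compounds shown, and "the series" means these compounds.

Measured so far in a functional assay on HepG2 cells (Homo sapiens) for inhibition, read by MTT assay, with a stated time of 72 h; a higher number here means a weaker inhibitor, a lower number a stronger inhibitor:
compound 1, `CN(C(=O)NC(=O)c1ccc(Cl)cc1Cl)c1nc(C(F)(F)F)c(C(=O)N/N=C/c2ccc(C(F)(F)F)cc2)s1`: 12.4 ug/mL
compound 2, `Cc1nc(N(C)C(=O)NC(=O)c2c(F)cccc2F)sc1C(=O)N/N=C/c1ccccc1C(F)(F)F`: 1.11 ug/mL
compound 3, `CN(C(=O)NC(=O)c1c(F)cccc1F)c1nc(C(F)(F)F)c(C(=O)N/N=C/c2ccccc2C(F)(F)F)s1`: 26.1 ug/mL

Compound 2 gives the lowest number of the three; compound 1 and compound 3 both lie beyond the scatter from it. Compound 4, `COc1cc(/C=N/NC(=O)c2sc(N(C)C(=O)NC(=O)c3c(F)cccc3F)nc2C)cc(OC)c1OC`, is not yet measured. It differs from compound 2 in one place: 3,4,5-trimethoxyphenyl in place of 2-(trifluoromethyl)phenyl on a carbon with a double bond to nitrogen. Within the data shown here, the only measured single step, a 24-fold higher number from compound 2 to compound 3 (1.37 log units; beyond the scatter), concerns the group on the shared core, not the carbon with a double bond to nitrogen, so no measured step bears directly on this change. With no guide at that place, only a modest step is expected, a 1.8-fold higher number from compound 2 to compound 4 (0.26 log units; within the scatter), and compound 4 is estimated at 2 ug/mL, in the range 0.5 ug/mL to 10 ug/mL.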

Compound 4, half-maximal inhibitory concentration: > 100 ug/mL
Compound 4: a limit, no number; the forecaster's own chance of this, stated with the estimate: 5%; middle value at least 50-fold (1.69 log units) away from the limit.
By their numbers in this assay, from the lowest: compound 2; then compound 1; then compound 3. At a limit, above all of these: compound 4.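

At the carbon with a double bond to nitrogen, the group strongly affects the result in this assay: 3,4,5-trimethoxyphenyl in place of 2-(trifluoromethyl)phenyl gives an at least 90-fold higher number from compound 2 to compound 4 (1.95 log units; beyond the scatter). Among these compounds, this is the first step read at this place, and it shows that the place is not tolerant of every aryl group. The value of compound 4 is a limit of the assay, not a number: the limit of > 100 ug/mL in this assay, at which 1 of the 4 values shown sits.

From the compounds shown here alone, it remains open whether the change in the number follows from the entering methoxy groups or from the loss of trifluoromethyl. A plain phenyl or a phenyl with a single methoxy group at this place would separate the two.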